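The source may report more compounds than this note shows. Statements on the series, on what has been measured and on what is new or still open speak of the compounds shown alone.

Compound 2, whose structure is `N=C(S)CCn1nc(-c2ccccc2)ccc1=S`, gives 73.4 mg/kg in a functional assay on the whole organism (stomach) with Rattus norvegicus as the target; a higher number here means that more compound is needed for the effect, a lower number that less compound is needed. Compound 3, with the structure `C/N=C(\S)C(C)Cn1ncccc1=O`, gives 100 mg/kg in this assay, and this number lies within the usual scatter of the value of compound 2. For compound 1, with the structure `N=C(S)CCN1N=C(c2ccc(Cl)c(Cl)c2)CCC1=O`, this assay reports only a limit, > 100 mg/kg, which is the limit of > 100 mg/kg in this assay, at which 1 of the 3 values shown sits.

Compound 4, with the structure `Cc1ccc(=S)n(CCC(=N)S)n1`, has not yet been measured in this assay. It differs from compound 2 in one place: methyl in place of phenyl on an aromatic carbon. Among the measured compounds shown here, no measured pair shows a step of this kind, so the direction of the step is uncertain. Given that compound 3, which carries no phenyl, gives 100 mg/kg and sits within the scatter of compound 2, the expected step from compound 2 to compound 4 is a 1.2-fold higher number from compound 2 to compound 4 (0.09 log units; within the scatter), no larger than the scatter. Compound 4 is therefore estimated at 90 mg/kg in this assay, with a range from 40 mg/kg to 200 mg/kg.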

Compound 4, dose for half-maximal effect: 100 mg/kg
Beside the measured number, compound 4's estimate is 1.1-fold (0.05 log units) below it; the measured number falls inside the stated range.
By their numbers in this assay, from the lowest: compounds 2, 3 and 4 (each within the scatter of the next).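

In this assay, among the compounds shown here, the exchange of methyl for phenyl on the aromatic carbon next to the ring nitrogen gives a 1.4-fold higher number from compound 2 to compound 4 (0.13 log units; within the scatter), the first step that can be read at this position. The shared core therefore loses a six-membered aromatic ring of carbon only, five heavy atoms fewer in all, and compound 2 and compound 4 still cannot be told apart in this assay. Compound 1 offers no number for comparison, as its value is a limit: the limit of > 100 mg/kg in this assay, at which 1 of the 4 values shown sits.

The compounds shown leave open whether another group on this aromatic carbon, such as an amine, a carboxylic acid or a longer chain, would give a number beyond the scatter of compound 2. They also leave open whether methyl in place of phenyl would read the same on any other core.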